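Trimming the benzyl on the ring nitrogen

This account rests on a few compounds, and the source may have more. Where it says the series, first, only, none or still open, it means among the compounds named here.

Compound 2 `Nc1ccc(/C=C2\SC(=O)N(Cc3ccccc3)C2=O)cc1` carries a benzyl group on the amide-type nitrogen of its ring and a free amine on the aromatic ring beyond the double bond. In a functional assay on CCRF-CEM cells (Homo sapiens) for cytotoxicity, read by cell counting, with a stated time of 3 days (on this read-out higher numbers stand for weaker inhibition and lower numbers for stronger inhibition), compound 2 gives 42000 nM, the second highest of the three numbers measured. Its closest companion is compound 1 `CC(C)(C)c1ccc(CN2C(=O)S/C(=C\c3ccc(N)cc3)C2=O)cc1`, which gives 66000 nM in this assay; the step of a 1.6-fold lower number from compound 1 to compound 2 (0.20 log units; within the scatter). Compound 3 `C=C(Br)C(=O)Nc1ccc(/C=C2\SC(=O)N(Cc3ccccc3)C2=O)cc1` gives 2300 nM in this assay, and the step of an 18-fold lower number from compound 2 to compound 3 (1.26 log units; beyond the scatter).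

Compound 4 `CCN1C(=O)S/C(=C\c2ccc(N)cc2)C1=O` differs from compound 2 by methyl in place of phenyl on a saturated chain carbon bound to an amide-type nitrogen in a ring. For the measured compounds named here, no measured step touches this exact change. The step from compound 1 to compound 2 altered the same phenyl that leaves in compound 4 and stayed within the scatter, while the large step from compound 2 to compound 3 concerned the amine on the other aromatic ring, not the group on the nitrogen. Only the first of these bears on compound 4, and it points to a small effect of changes around the benzyl group in this set. Compound 4 is therefore expected to show a 1.4-fold higher number from compound 2 to compound 4 (0.15 log units; within the scatter). The estimate for compound 4 in this assay is 60000 nM, with a range from 20000 nM to 180000 nM.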

Compound 4, half-maximal inhibitory concentration: 91000 nM
The estimate for compound 4 lay 1.5-fold (0.18 log units) below the measured number; the range from low to high includes it.
By their numbers in this assay, from the lowest: compound 3; then compounds 2, 1 and 4 (each within the scatter of the next, the first and the last beyond it).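

Cutting benzyl to ethyl, with methyl in place of phenyl on a saturated chain carbon bound to an amide-type nitrogen in a ring, gives a 2.2-fold higher number from compound 2 to compound 4 (0.34 log units; beyond the scatter) in this assay and is the first change at this place to pass beyond the scatter. The earlier step, a 1.6-fold lower number from compound 1 to compound 2 (0.20 log units; within the scatter), concerned only the tert-butyl on the phenyl, whereas this one removes the whole aromatic ring and shows that the number does respond to the group on the nitrogen, though the step is only modest. Nothing available bears on why the number rises.

Benzyl and ethyl differ in both ring and chain, so the compounds shown leave open which of the two matters, and a longer chain such as propyl or butyl, a cyclohexylmethyl group, or a chain ending in an amine or a carboxylic acid on this nitrogen would help to separate them. They also leave open whether the (1-bromoethenyl)carbonyl group on the amine of compound 3 would lower the number as much with ethyl in place of benzyl.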